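A few compounds are considered here, and "the series" means these few. Any claim that something is new, unique, unknown or untested is made for them only; others in the source may bear on it.

- compound 1 `COc1ccc([C@H](O)COC(=O)/C=C/c2ccccc2)cc1OC`: 24300 nM
- compound 2 `COc1ccccc1[C@H](O)COC(=O)/C=C/c1ccccc1`: 14000 nM
- compound 3 `COc1ccccc1[C@@H](O)COC(=O)/C=C/c1ccccc1`: 51700 nM

In an ADME assay on Vero cells (Chlorocebus sabaeus) for cytotoxicity, read by MTT assay, with a stated time of 72 h (on this read-out lower numbers stand for higher toxicity in this test and higher numbers for lower toxicity in this test), compound 3 gives the highest of these three numbers, 51700 nM. Compound 4 `O=C(/C=C/c1ccccc1)OC[C@H](O)c1ccccc1` has hydrogen in place of methoxy on an aromatic carbon. Going by the values given here, the one measured step, a 3.7-fold higher number from compound 2 to compound 3 (0.57 log units; beyond the scatter), is tied to the fact that compounds 2 and 3 differ only in the configuration as drawn, so it offers only a rough sense of scale and no direct guide to losing a methoxy. Among the compounds with values here, no measured step removes that group, so the direction stays open and no change beyond the scatter is expected. The expected change is a 1.1-fold lower number from compound 3 to compound 4 (0.06 log units; within the scatter). For compound 4 the estimated value is 45000 nM, with an expected range from 18000 nM to 110000 nM.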

Compound 4, half-maximal cytotoxic concentration: 30300 nM
Compound 4: the middle estimate sits 1.5-fold (0.17 log units) above what was measured, within the range that was stated.
By their numbers in this assay, from the lowest: compounds 2, 1, 4 and 3 (each within the scatter of the next, the first and the last beyond it).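

Replacing methoxy with hydrogen on an aromatic carbon, ortho to a large group, gives the first measured result for a change at this position: in this assay, there is a 1.7-fold lower number from compound 3 to compound 4 (0.23 log units; within the scatter). Compound 3 and compound 4 therefore cannot be told apart in this test, so the methoxy is not needed to keep the number in this range. Nothing given here bears on the reason for this result.

The compounds shown leave open how an amine or a carboxylic acid at this position would read. They also leave open whether the same swap gives a similar result in the configuration drawn for compound 2.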